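Ring Size at the Amide Side Chain: Compound 4 Expected

The source may report more compounds than this note shows. Statements on the series, on what has been measured and on what is new or still open speak of the compounds shown alone.

In a functional assay on HepG2 cells (Homo sapiens) for antiproliferative activity, read by MTT assay, with a stated time of 48 h (a higher number here means a weaker inhibitor, a lower number a stronger inhibitor), compound 1 `O=C(CN1CCCC1)Nc1ccc2ncnc(Nc3ccc(Cl)cc3)c2c1` gives 18000 nM. Compound 2 `O=C(CN1CCCCC1)Nc1ccc2ncnc(Nc3ccc(Cl)cc3)c2c1` carries piperidin-1-yl in place of pyrrolidin-1-yl on a saturated chain carbon bound to a carbonyl carbon and in this assay compound 2 gives 16000 nM; the step is a 1.1-fold lower number from compound 1 to compound 2 (0.05 log units; within the scatter). Compound 3 `O=C(CN1CCCC1)Nc1ccc2ncnc(Nc3ccc(Br)cc3)c2c1` gives > 100000 nM in this assay, which is a limit of the assay and not a number. The cores of compound 1 and compound 3 differ by bromo in place of chloro on an aromatic carbon, and the step is an at least 5.5-fold higher number from compound 1 to compound 3 (0.74 log units; beyond the scatter), compound 3 standing at the limit of > 100000 nM in this assay, at which 1 of the 3 values shown sits.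

Compound 4 `O=C(CN1CCCCC1)Nc1ccc2ncnc(Nc3ccc(Br)cc3)c2c1` is not yet measured. It differs from compound 3 by piperidin-1-yl in place of pyrrolidin-1-yl on a saturated chain carbon bound to a carbonyl carbon, the same change, at the same place, as from compound 1 to compound 2. Because that change gave a 1.1-fold lower number from compound 1 to compound 2 (0.05 log units; within the scatter), compound 4 is expected to show a step that the limit leaves unreadable from compound 3 to compound 4 in this assay. The estimate for compound 4 is 110000 nM, expected between 40000 nM and 300000 nM, most likely reported again as a limit.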

Compound 4, half-maximal inhibitory concentration: > 100000 nM
Compound 4 was reported as a limit; the forecaster's own chance of this, stated with the estimate: 70%; the middle value lies beyond the limit too.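

In this assay, the step from pyrrolidin-1-yl to piperidin-1-yl cannot be read on the core of compound 3, as both members of that pair are limits of the assay and not numbers: the limit of > 100000 nM in this assay, at which 2 of the 4 values shown sit. Bromo in place of chloro gives an at least 6.2-fold higher number from compound 2 to compound 4 (0.79 log units; beyond the scatter), and with the earlier step it points the same way on both side chains: the same change on two cores in this assay, an at least 5.5-fold higher number (0.74 log units; beyond the scatter) from compound 1 to compound 3 and an at least 6.2-fold higher number (0.79 log units; beyond the scatter) from compound 2 to compound 4; the limit leaves it open whether they differ. The higher number with bromo thus carries over from one side chain to the other, but its true size on either is not shown, nor is whether the ring change has any effect once bromo is present.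

The compounds shown leave open how other groups on that aromatic carbon, such as fluoro or methoxy, would read. They also leave open other amines on the side chain, such as morpholin-4-yl, and a longer chain before the amine.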